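This account rests on a few compounds, and the source may have more. Where it says the series, first, only, none or still open, it means among the compounds named here.

Compound 1 `Cc1c(Cc2ccc(C(C)(C)C)cc2)c(=O)oc2cc(OCC(O)CN3CCC(C(N)=O)CC3)ccc12`: 14700 nM
Compound 2 `CC(=O)C1CCN(CC(O)COc2ccc3c(C)c(Cc4cccc([N+](=O)[O-])c4)c(=O)oc3c2)CC1`: 90500 nM

In an ADME assay on A549 cells (Homo sapiens) for cytotoxicity, read by CellTiter-Glo (on this read-out lower numbers stand for higher toxicity in this test and higher numbers for lower toxicity in this test), compound 1 gives the lower of the two numbers, and compound 2 sits above it by a gap beyond the usual scatter. Compound 3 `Cc1c(Cc2ccc(-c3ccc(C#N)c(F)c3)cc2)c(=O)oc2cc(OCC(O)CN3CCC(C(N)=O)CC3)ccc12` has not been measured yet. It differs from compound 1 in one place: 4-cyano-3-fluorophenyl in place of tert-butyl on an aromatic carbon. Within the data shown here, no measured pair shows a comparable change, so the direction cannot be read off the data. The step of a 1.8-fold lower number from compound 1 to compound 3 (0.26 log units; within the scatter) is expected to be modest, toward a lower number. Compound 3 is estimated at 8000 nM, within a range from 2500 nM to 25000 nM.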

Compound 3, half-maximal cytotoxic concentration: 29100 nM
Compound 3: the middle estimate sits 3.6-fold (0.56 log units) below what was measured, outside the stated range (above it).
By their numbers in this assay, from the lowest: compounds 1 and 3 (each within the scatter of the next); then compound 2.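

In this assay, replacing tert-butyl (4 heavy atoms, no ring) with 4-cyano-3-fluorophenyl (9 heavy atoms, an aromatic ring and a nitrile) at this aromatic carbon gives a 2.0-fold higher number from compound 1 to compound 3 (0.30 log units; within the scatter) and so no clear change. At this position, then, a much larger group carrying a ring leaves the read-out within normal repeat variation, at least for this one pair. No available data explain this result. On these data alone, whether an amine or a carboxylic acid at this carbon would shift the number beyond that variation remains open.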